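Shifting the aryl substituent on the triazole-linked core

The compounds below may be only part of what the source reports. "The series", "measured", "known", "first", "only" and "open" are said of these compounds alone.

Within the data shown here, compound 3 `CCCCCc1ccc(-c2cn(C[C@H](O)[C@H]3OC(=O)C(OCc4ccccc4)=C3OCc3ccccc3)nn2)cc1` gives 13800 nM in a functional assay on HCT-116 cells (Homo sapiens) for antiproliferative activity, read by MTT assay, with a stated time of 72 h (on this read-out higher numbers stand for weaker inhibition and lower numbers for stronger inhibition), which places it second highest of the three numbers so far. Compound 1 `O=C1O[C@H]([C@@H](O)Cn2cc(-c3ccc(Br)cc3)nn2)C(OCc2ccccc2)=C1OCc1ccccc1` gives 9420 nM, and compound 2 `O=C1O[C@H]([C@@H](O)Cn2cc(-c3cccc(O)c3)nn2)C(OCc2ccccc2)=C1OCc1ccccc1` gives 42900 nM. Compound 4 `COc1ccccc1-c1cn(C[C@H](O)[C@H]2OC(=O)C(OCc3ccccc3)=C2OCc2ccccc2)nn1` has not yet been measured; it differs from compound 3 by 2-methoxyphenyl in place of 4-pentylphenyl on an aromatic carbon. Two earlier steps bear on this change. The swap of pentyl for bromo was a 1.5-fold higher number from compound 1 to compound 3 (0.17 log units; within the scatter), so a plain carbon chain on that ring made little difference. The swap to a 3-hydroxyphenyl, however, was a 4.6-fold higher number from compound 1 to compound 2 (0.66 log units; beyond the scatter), and going back from that ring to the 4-pentylphenyl was a 3.1-fold lower number from compound 2 to compound 3 (0.49 log units; beyond the scatter). An oxygen on the aryl ring therefore went with a higher number once, though a methoxy group is not a hydroxyl and no 2-substituted aryl has been measured. A small step upward is expected in this assay, about a 1.3-fold higher number from compound 3 to compound 4 (0.12 log units; within the scatter), with wide uncertainty. Compound 4 is estimated at 18000 nM, in a range from 6000 nM to 50000 nM.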

Compound 4, half-maximal inhibitory concentration: > 100000 nM
Compound 4 was reported as a limit; the forecaster's own chance of this, stated with the estimate: 5%; middle value at least 5.5-fold (0.74 log units) from the limit.
By their numbers in this assay, from the lowest: compounds 1 and 3 (each within the scatter of the next); then compound 2. At a limit, above all of these: compound 4.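

In this assay, the reading for compound 4 is a limit of the assay and not a number: the limit of > 100000 nM in this assay, at which 1 of the 4 values shown sits. Replacing the 4-pentylphenyl with 2-methoxyphenyl gives an at least 7.2-fold higher number from compound 3 to compound 4 (0.86 log units; beyond the scatter), and the comparisons with the other two aryl groups give an at least 10-fold higher number from compound 1 to compound 4 (1.02 log units; beyond the scatter) and an at least 2.3-fold higher number from compound 2 to compound 4 (0.36 log units; beyond the scatter). The aryl group on this aromatic carbon can therefore carry the read-out past all three earlier numbers, which the spread among compound 1, compound 2 and compound 3 had not shown.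

The compounds shown do not separate the methoxy group itself from its place on the ring, so it remains open whether a 4-methoxyphenyl or a 2-methylphenyl would read like compound 4 or like compound 1. From the compounds shown here alone, the full size of all three steps also stays open, since each rests on the limit.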